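The compounds below may be only part of what the source reports. "The series", "measured", "known", "first", "only" and "open" are said of these compounds alone.

Of the compounds shown here, three sharing one core have been measured in an assay on a protein complex for inhibition of NEDD8 activating enzyme (Homo sapiens), read by HTRF, with a stated time of 2 h, in the presence of a further agent that is not named here; a lower number here means a stronger inhibitor, a higher number a weaker inhibitor. Compound 1 `NS(=O)(=O)OC[C@@H]1C[C@@H](n2nnc3c(NCc4ccco4)ncnc32)C[C@@H]1O` gives 30.6 nM. Compound 2 `NS(=O)(=O)OC[C@@H]1C[C@@H](n2nnc3c(NCCCc4ccccc4)ncnc32)C[C@@H]1O` gives 149 nM. Compound 3 `COC(=O)[C@H]1C=C[C@@H](Nc2ncnc3c2nnn3[C@@H]2C[C@@H](COS(N)(=O)=O)[C@@H](O)C2)C1` gives 80.9 nM, the second highest of the three numbers: it sits close to compound 2, as a 1.8-fold lower number from compound 2 to compound 3 (0.27 log units; within the scatter), and further from compound 1, as a 2.6-fold higher number from compound 1 to compound 3 (0.42 log units; beyond the scatter).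

The next compound, compound 4 `NS(=O)(=O)OC[C@@H]1C[C@@H](n2nnc3c(Nc4cnc5ccccn45)ncnc32)C[C@@H]1O`, alters the group on the nitrogen on the aromatic ring: a group of 9 heavy atoms (7 carbon, 2 nitrogen; one five-membered aromatic ring with 2 hetero atoms, one six-membered aromatic ring with 1 hetero atom) in place of a group of 9 heavy atoms (7 carbon, 2 oxygen; one five-membered non-aromatic ring of carbon only), on a nitrogen on an aromatic ring. Going by the values given here, no measured step replaces a five-membered non-aromatic ring of carbon only with aromatic rings, so the earlier steps guide only loosely. Among the compounds with values here, both earlier changes at this position shifted the number modestly, a 4.9-fold higher number from compound 1 to compound 2 (0.69 log units; beyond the scatter) and a 2.6-fold higher number from compound 1 to compound 3 (0.42 log units; beyond the scatter), and compound 1, the only one whose group contains an aromatic ring, has the lowest number. Compound 4 is therefore expected to come out somewhat lower, with an estimated step of a 1.6-fold lower number from compound 3 to compound 4 (0.21 log units; within the scatter), though a step within the scatter would not be surprising. The estimate for compound 4 is 50 nM, with a likely range from 15 nM to 200 nM.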

Compound 4, half-maximal inhibitory concentration: > 10000 nM
Compound 4: only a limit was reported; the forecaster's own chance of this, stated with the estimate: 5%; at least 200-fold (2.30 log units) between middle value and limit.
By their numbers in this assay, from the lowest: compound 1; then compounds 3 and 2 (each within the scatter of the next). At a limit, above all of these: compound 4.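

In this assay, compound 4 gives only a limit, not a number: the limit of > 10000 nM in this assay, at which 1 of the 4 values shown sits.

Earlier changes to the group on this nitrogen moved the number only modestly, but this group gives a large step from every measured compound (an at least 120-fold higher number from compound 3 to compound 4 (2.09 log units; beyond the scatter)) (an at least 67-fold higher number from compound 2 to compound 4 (1.82 log units; beyond the scatter)) (an at least 320-fold higher number from compound 1 to compound 4 (2.51 log units; beyond the scatter)). Going by these compounds alone, the group leaving compound 3 and the one entering compound 4 have the same counts of heavy atoms, hydrogen-bond donors and acceptors, so those counts alone do not separate a measurable number from a limit, and the aromatic rings in compounds 1 and 2 show that an aromatic ring in the group does not by itself bring such a limit.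

As far as these compounds go, it remains open whether the loss belongs to the whole two-ring group or to an aromatic ring bound straight to this nitrogen, which a simple phenyl or pyridyl group there could test. From the compounds shown here alone, how far the true value of compound 4 lies beyond its limit also remains open.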